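The source may report more compounds than this note shows. Statements on the series, on what has been measured and on what is new or still open speak of the compounds shown alone.

Measured compounds: compound 1 `Cc1c(N(C)C)nc(CCCCCCCCCCO)c(O)c1C` with 50%; compound 2 `CCCCCCCCCCCCCCCCCCCc1c(C)c(N(C)C)nc(C)c1O` with 106%.

In a functional assay on cells (Lymphocyte), read by a luciferase reporter and ATP content, with a stated time of 48 h, tested at 5 uM (on this read-out higher numbers stand for a weaker effect at the one concentration tested and lower numbers for a stronger effect), compound 1 gives 50%, the lower of the two numbers, and compound 2 gives 106%, a value beyond the scatter above it. Compound 3 `CCCCCCCCCCCCCCCCCCCc1nc(N(C)C)c(C)c(C)c1O` is not yet measured. The change from compound 1 to compound 3 is nonyl in place of hydroxy on a saturated chain carbon, ten or more bonds along the chain from an aromatic carbon. Going by the values given here, no step between two measured compounds of this kind is available, so the size of this step is open. Compound 2, which also carries a long saturated chain with no hydroxy on it, gives 106%, and on that basis a step upward in this assay toward a weaker effect is expected, beyond the scatter. The expected value for compound 3 is 90%, within 65% to 110%, which corresponds to an expected step of a number 40 percentage points higher from compound 1 to compound 3 (beyond the scatter).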

Compound 3, a percentage reported as activity, at one concentration (the size of the read-out at that concentration, not a potency): 102%
The estimate for compound 3 lay 12 percentage points below the measured number; low and high end bracket the measured number.
By their numbers in this assay, from the lowest: compound 1; then compounds 3 and 2 (each within the scatter of the next).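

In this assay, nonyl in place of hydroxy on a saturated chain carbon, ten or more bonds along the chain from an aromatic carbon, gives a number 52 percentage points higher from compound 1 to compound 3 (beyond the scatter). Going by these compounds alone, this is the first direct reading of a change at this place, and it shows that the place is not indifferent to what it carries. Of this pair, only compound 1, at 50%, keeps the stronger effect, and compound 3, with nonyl, does not.

The step removes the hydroxy and lengthens the chain at once, so the compounds shown cannot tell which of the two matters. On these data alone, it also remains open how an amine, a carboxylic acid or a methoxy would read in place of the hydroxy on the same chain, or how a shorter chain carrying the hydroxy would read. No measurement at hand accounts for the size of this step.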